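A few compounds are considered here, and "the series" means these few. Any claim that something is new, unique, unknown or untested is made for them only; others in the source may bear on it.

In a functional assay on PC-3 cells (Homo sapiens) for cytotoxicity, read by MTT assay (on this read-out higher numbers stand for weaker inhibition and lower numbers for stronger inhibition), compound 1 `COc1ccc(CSc2nnc([C@@H](C)c3ccc4cc(OC)ccc4c3)n2-c2ccc(Cl)cc2)cc1` is reported only as a limit, <= 400000 nM. Compound 2 `COc1cccc(CSc2nnc([C@@H](C)c3ccc4cc(OC)ccc4c3)n2-c2ccc(Cl)cc2)c1` gives 138000 nM and compound 3 `COc1ccc2cc([C@H](C)c3nnc(SCc4ccc(C)cc4)n3-c3ccc(F)cc3)ccc2c1` gives 229000 nM, two values within the scatter of each other. Compound 4 `COc1ccc2cc([C@H](C)c3nnc(SCc4ccc(F)cc4)n3-c3ccc(F)cc3)ccc2c1` departs from compound 3 at a single place: fluoro in place of methyl on an aromatic carbon. This turns 4-methylbenzyl into 4-fluorobenzyl. Among the measured compounds shown here, the only measured step, a step that the limit leaves unreadable from compound 1 to compound 2, concerns a different change and offers no size for this one. With no measured guide, no shift beyond the scatter is expected, and the estimated step is a 1.1-fold lower number from compound 3 to compound 4 (0.06 log units; within the scatter). Compound 4 is expected at 200000 nM, with an estimated range of 90000 nM to 400000 nM.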

Compound 4, half-maximal inhibitory concentration: <= 400000 nM
Compound 4: no number, only a limit; the forecaster's own chance of this, stated with the estimate: 20%; the middle value is on the limit's open side.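

Compound 4, like compound 1, is reported only as a limit, so no size can be read for the step from compound 3 to compound 4: the limit of <= 400000 nM in this assay, at which 2 of the 4 values shown sit.

The compounds shown leave open whether fluoro in place of methyl on an aromatic carbon shifts the read-out in this assay at all.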